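Hydroxybutyl for phenyl on the aminomethyl arm

This account rests on a few compounds, and the source may have more. Where it says the series, first, only, none or still open, it means among the compounds named here.

Compound 3 `CSc1nc(NCc2ccccc2)c2cccnc2n1` and compound 2 `CSc1nc(NCc2ccccc2)c2ccccc2n1` carry the same phenyl-bearing arm on different cores; the difference between the two cores is not broken down here. In a functional assay on HTB-54 cells (Homo sapiens) for cytotoxicity, read by MTT assay, with a stated time of 72 h (on this read-out higher numbers stand for weaker inhibition of growth and lower numbers for stronger inhibition of growth), compound 3 gives 5080 nM. Compound 2 gives 37900 nM in this assay, the higher of the two numbers and beyond the scatter from compound 3.

Compound 1 `CSc1nc(NCCCCCO)c2cccnc2n1` differs from compound 3 by one change: 4-hydroxybutyl in place of phenyl on a saturated chain carbon bound to a nitrogen on an aromatic ring. In this assay compound 1 reaches only a limit of the assay, > 100000 nM. As far as these compounds go, the step of an at least 19-fold higher number from compound 3 to compound 1 (1.29 log units; beyond the scatter) is therefore bounded by the limit of > 100000 nM in this assay, at which 1 of the 3 values shown sits, and its full size is unknown.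

Compound 4 `CSc1nc(NCCCCCO)c2ccccc2n1` applies the same change to compound 2: 4-hydroxybutyl in place of phenyl on a saturated chain carbon bound to a nitrogen on an aromatic ring. The place is identical word for word, so the same change is expected to act in the same direction. Set beside the earlier step, the expected step of a 7.9-fold higher number from compound 2 to compound 4 (0.90 log units; beyond the scatter) starts from a high number, because compound 2 already gives 37900 nM. Compound 4 is therefore expected to give about 300000 nM in this assay, most probably reported only as a limit.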

Compound 4, concentration for 50% growth inhibition: 31400 nM
Compound 4: the middle estimate sits 9.6-fold (0.98 log units) above what was measured, outside the stated range (below it).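

In this assay, 4-hydroxybutyl in place of phenyl does not carry over from one core to the other with the same result: the same change on two cores in this assay, an at least 19-fold higher number (1.29 log units; beyond the scatter) from compound 3 to compound 1 and a 1.2-fold lower number (0.08 log units; within the scatter) from compound 2 to compound 4, at least 23-fold (1.37 log units) apart, beyond the scatter of two such steps. On the core of compound 2 the step is a 1.2-fold lower number from compound 2 to compound 4 (0.08 log units; within the scatter), so no difference between the two arms can be read on that core. The two pairs show that the outcome of this change depends on the core, but not why, and the step on the core of compound 3 is only bounded: the limit of > 100000 nM in this assay, at which 1 of the 4 values shown sits.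

The compounds shown leave open whether a terminal amine, a terminal carboxylic acid or a longer chain in place of 4-hydroxybutyl would behave differently on the two cores. They also leave open the true size of the step to compound 1, and whether the gap between the cores would hold for any arm other than these two.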